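The compounds below may be only part of what the source reports. "The series", "measured", "known", "first", "only" and "open" are said of these compounds alone.

Measured so far in an ADME assay on BCBL1 cells (Homo sapiens) for cytotoxicity, with a stated time of 7 days; on this read-out lower numbers stand for higher toxicity in this test and higher numbers for lower toxicity in this test:
- compound 1 `Nc1nc(NCc2ccccc2)c2ncn(/C=C3/CC3(CO)CO)c2n1`: 19900 nM
- compound 2 `CCCNc1nc(N)nc2c1ncn2/C=C1/CC1(CO)CO`: > 20000 nM
- compound 3 `Nc1nc(NC2CCCCC2)c2ncn(/C=C3/CC3(CO)CO)c2n1`: > 20000 nM

Compound 3 gives > 20000 nM, which is a limit and not a number. Compound 2 gives > 20000 nM, also a limit. The series therefore stands mostly at the limit of > 20000 nM in this assay, at which 2 of the 3 values shown sit. Within the data shown here, compound 1 is the only one with a number, at 19900 nM.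

The next change replaces cyclohexylamino with isopropylsulfanyl on an aromatic carbon, giving compound 4 `CC(C)Sc1nc(N)nc2c1ncn2/C=C1/CC1(CO)CO`: isopropylsulfanyl in place of cyclohexylamino on an aromatic carbon.

The measured steps give little guidance on size. They are a number no lower from compound 1 to compound 2 (the limit leaves the size open), a number no lower from compound 1 to compound 3 (the limit leaves the size open) and a step that the two limits leave unreadable from compound 2 to compound 3, and none can be read as a size. Among the measured compounds shown here, all three also keep a nitrogen on the aromatic carbon, so the sulfur-linked isopropylsulfanyl group has no measured precedent in this set. With compound 1 at 19900 nM as the only numerical anchor, no large move is expected in this assay. A modest shift toward lower numbers is possible, and another limit is somewhat more likely than a number. The expected step is an at least 1.1-fold lower number from compound 3 to compound 4 (0.04 log units; that floor lies within the scatter). For compound 4 the estimated value is 18000 nM, with an expected range from 8000 nM to 30000 nM.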

Compound 4, half-maximal cytotoxic concentration: > 20000 nM
Compound 4 was reported as a limit; the forecaster's own chance of this, stated with the estimate: 60%; middle value at least 1.1-fold (0.04 log units) from the limit.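

In this assay compound 4 is reported as a limit and not a number, so this position now holds a sulfur-linked group as well as the nitrogen-linked groups of compound 1, compound 2 and compound 3, but without a size for the change. Among these compounds, the only step with a direction is a number no lower from compound 1 to compound 4 (the limit leaves the size open), while the steps to compound 4 from compound 2 and from compound 3 cannot be read, as both ends of each are limits. The new information is that isopropylsulfanyl, with no ring and no hydrogen-bond donor, falls in the same place as the propylamino and cyclohexylamino compounds: the limit of > 20000 nM in this assay, at which 3 of the 4 values shown sit.

Going by these compounds, whether a sulfur-linked group with a ring, such as phenylsulfanyl, or a longer chain on sulfur would give a number in this assay stays open. The values behind the limits of compound 2, compound 3 and compound 4 also remain unknown, so no order among these three can be drawn.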